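A few compounds are considered here, and "the series" means these few. Any claim that something is new, unique, unknown or untested is made for them only; others in the source may bear on it.

Measured so far in a functional assay on HeLa cells (Homo sapiens) for cytotoxicity, read by MTT assay, with a stated time of 72 h; a higher number here means a weaker inhibitor, a lower number a stronger inhibitor:
- compound 1 `Cc1cccc(/C(N)=N/NC(=S)N2CCSCC2)n1` gives 1800 nM
- compound 2 `N/C(=N\NC(=S)N1CCSCC1)c1ccccn1` gives 7800 nM
- compound 3 `N/C(=N\NC(=S)N1CCCCC1)c1ccccn1` gives 3800 nM

Compound 1 holds the lowest number of the three, and both of its gaps are beyond the scatter: the nearest is compound 3 and the furthest compound 2. Within the set, the step of a 4.3-fold higher number from compound 1 to compound 2 (0.64 log units; beyond the scatter) came with hydrogen in place of methyl on an aromatic carbon, and the step of a 2.1-fold lower number from compound 2 to compound 3 (0.31 log units; beyond the scatter) came with piperidin-1-yl in place of thiomorpholin-4-yl on a thiocarbonyl carbon.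

The next compound, compound 4 `Cc1cccc(/C(N)=N/NC(=S)N2CCCC2)n1`, keeps the methyl of compound 1 and differs from it only at the thiocarbonyl carbon: pyrrolidin-1-yl in place of thiomorpholin-4-yl on a thiocarbonyl carbon. Within the data shown here, no measured pair carries this exact ring exchange. Among the measured compounds shown here, the one step that bears on it is a 2.1-fold lower number from compound 2 to compound 3 (0.31 log units; beyond the scatter), where a six-membered ring with two hetero atoms gave way to a carbocyclic amine ring and the number fell modestly. Pyrrolidin-1-yl is a smaller ring than piperidin-1-yl, so that step is only a rough guide; the expectation is a step of similar size and direction in this assay , or none beyond the scatter, from compound 1 to compound 4, namely a 1.5-fold lower number from compound 1 to compound 4 (0.18 log units; within the scatter). Compound 4 is therefore estimated at 1200 nM, with a range from 500 nM to 3200 nM.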

Compound 4, half-maximal inhibitory concentration: 2700 nM
Estimate against measurement, compound 4: 2.3-fold (0.35 log units) below; the measured number falls inside the stated range.
By their numbers in this assay, from the lowest: compounds 1, 4 and 3 (each within the scatter of the next, the first and the last beyond it); then compound 2.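

In this assay, among these compounds, a 1.5-fold higher number from compound 1 to compound 4 (0.18 log units; within the scatter) is the first ring exchange on a thiocarbonyl carbon read with the methyl on the aromatic carbon, and it shows that in this core thiomorpholin-4-yl can give way to pyrrolidin-1-yl without a step beyond the scatter. Among the compounds shown here, the six-membered ring with 2 hetero atoms is therefore not needed to keep compound 4 level with compound 1 here, whereas the only earlier ring exchange, a 2.1-fold lower number from compound 2 to compound 3 (0.31 log units; beyond the scatter), was read on the core with hydrogen on that aromatic carbon and with piperidin-1-yl entering. Nothing at hand accounts for how this exchange reads at this position.

The two exchanges differ in both the entering ring and the group on the aromatic carbon, so the compounds shown leave open whether either difference governs the outcome, and whether the methyl step holds when pyrrolidin-1-yl sits on the thiocarbonyl carbon. Also open, going by these compounds, is how this position responds to a morpholin-4-yl ring, a 4-methylpiperazin-1-yl ring or an open-chain dimethylamino group.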